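Halogen swap on the aroyl ring of compound 1

A few compounds are considered here, and "the series" means these few. Any claim that something is new, unique, unknown or untested is made for them only; others in the source may bear on it.

Measured in a functional assay on DU-145 cells (Homo sapiens) for inhibition, read by trypan blue exclusion, with a stated time of 96 h; a lower number here means a stronger inhibitor of growth, a higher number a weaker inhibitor of growth:
- compound 1 `O=C(/C(=C/c1ccc(Br)cc1)S(=O)(=O)Cc1ccc(I)cc1)c1ccc(I)cc1`: 20000 nM
- compound 2 `O=C(/C(=C/c1ccc(I)cc1)S(=O)(=O)Cc1ccc(I)cc1)c1ccc(I)cc1`: 50000 nM
- compound 3 `Cc1ccc(S/C(=C/c2ccc(F)cc2F)C(=O)c2ccc(Br)cc2)cc1`: > 100000 nM

The value for compound 3 is a limit of the assay and not a number. Compound 1 gives 20000 nM, the lower of the two actual numbers in this assay. Its nearest neighbour is reached by a 2.5-fold higher number from compound 1 to compound 2 (0.40 log units; beyond the scatter).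

Compound 4 `O=C(/C(=C/c1ccc(Br)cc1)S(=O)(=O)Cc1ccc(I)cc1)c1ccc(Br)cc1` has not yet been measured. The change from compound 1 is bromo in place of iodo on an aromatic carbon, or 4-iodophenyl to 4-bromophenyl within the carbonyl group.

Among the compounds with values here, only one measured step bears on this change: a 2.5-fold higher number from compound 1 to compound 2 (0.40 log units; beyond the scatter). That step is iodo in place of bromo on an aromatic carbon, so it is the same kind of exchange, but at another site and in the opposite sense. Read in reverse, it points towards a lower number for compound 4. Within the data shown here, with a single modest step from another site as the only guide, a small move is expected, and it may not clear the scatter.

The expected change is a 1.7-fold lower number from compound 1 to compound 4 (0.22 log units; within the scatter). Compound 4 is estimated at 12000 nM, with an expected range of 5000 nM to 35000 nM.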

Compound 4, concentration for 50% growth inhibition: > 50000 nM
Compound 4: only a limit was reported (the forecaster's own chance of this, stated with the estimate: 5%); middle value at least 4.1-fold (0.61 log units) from the limit.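

In this assay, the change from (4-iodophenyl)carbonyl to (4-bromophenyl)carbonyl gives an at least 2.5-fold higher number from compound 1 to compound 4 (0.39 log units; beyond the scatter), so the number at this position depends on which halogen is present. For compound 4 the reading is a limit of the assay and not a number: the limit of > 50000 nM in this assay, at which 1 of the 4 values shown sits. The earlier step, a 2.5-fold higher number from compound 1 to compound 2 (0.40 log units; beyond the scatter), is the reverse exchange at another site, and the direction does not carry over between the two sites: bromo in place of iodo raises the number here, iodo in place of bromo raises it there, and compound 1, with bromo at one site and iodo at the other, keeps the lowest actual number shown.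

On these data alone, how far compound 4 really lies from compound 1 stays open, as does whether any group other than iodo at this position, such as chloro, methoxy, an amine or a carboxylic acid, would hold or lower the number. Compound 2 and compound 4 differ in two places, so they give no separate reading of either site, and the pairing of halogens across the two sites rests on these few compounds alone.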